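The source may report more compounds than this note shows. Statements on the series, on what has been measured and on what is new or still open speak of the compounds shown alone.

Measured compounds:
- compound 1, `Nc1nc(N/N=C/c2cncs2)nc2c1ncn2[C@@H]1O[C@H](CO)[C@@H](O)[C@H]1O`: 22 nM
- compound 2, `Nc1nc(N/N=C/c2ccc3ncccc3c2)nc2c1ncn2[C@@H]1O[C@H](CO)[C@@H](O)[C@H]1O`: 9.8 nM

In an assay on CHO-K1 cells for displacement of a labelled ligand from adenosine receptor A1 (Homo sapiens), read by scintillation counting, with a stated time of 60 min (a lower number here means a stronger inhibitor, a higher number a weaker inhibitor), compound 2 gives 9.8 nM, the lowest of the two numbers shown; the nearest is compound 1, with a number higher by a 2.2-fold lower number from compound 1 to compound 2 (0.35 log units; beyond the scatter) when read from compound 1 to compound 2.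

Compound 3, `COc1ccc(/C=N/Nc2nc(N)c3ncn([C@@H]4O[C@H](CO)[C@@H](O)[C@H]4O)c3n2)cn1`, has not been measured in this assay. It differs from compound 2 in one place: 6-methoxypyridin-3-yl in place of quinolin-6-yl on a carbon with a double bond to nitrogen. Among the compounds with values here, the only measured step that touches this position is the exchange of the aryl group on the carbon double-bonded to nitrogen, which gave a 2.2-fold lower number from compound 1 to compound 2 (0.35 log units; beyond the scatter). That step is modest. Replacing quinolin-6-yl by a single six-membered aromatic ring is expected to move the number back toward that of compound 1, by a step of about a 1.6-fold higher number from compound 2 to compound 3 (0.21 log units; within the scatter). Compound 3 is therefore expected to give about 16 nM in this assay, within a range of 6 nM to 45 nM.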

Compound 3, inhibition constant: 2.6 nM
Estimate against measurement, compound 3: 6.2-fold (0.79 log units) above; the measured number lies below the stated range.
By their numbers in this assay, from the lowest: compound 3; then compound 2; then compound 1.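

In this assay, putting 6-methoxypyridin-3-yl on the carbon with a double bond to nitrogen gives a 3.8-fold lower number from compound 2 to compound 3 (0.58 log units; beyond the scatter), so the second aromatic ring of quinolin-6-yl is not required for a low number at this position. Against 1,3-thiazol-5-yl, the same group gives an 8.5-fold lower number from compound 1 to compound 3 (0.93 log units; beyond the scatter), which places the two groups with a single ring at opposite ends of the three compounds, with the two-ring quinolin-6-yl between them, so the number of rings alone does not set the order here. Nothing available accounts for the size of these steps.

The compounds shown leave open how much of the gain belongs to the methoxy group and how much to the pyridine ring itself. A plain pyridin-3-yl would separate the two, while an ethoxy group or an amine in place of the methoxy would show how far this position tolerates change.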